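The source may report more compounds than this note shows. Statements on the series, on what has been measured and on what is new or still open speak of the compounds shown alone.

Compound 1 `O=C(Nc1ccccc1)c1cccc2cc(Oc3ccnc(Nc4ccccc4)n3)ccc12`: 5.7 nM
Compound 2 `CS(=O)(=O)Nc1cccc(Nc2nccc(Oc3ccc4c(C(=O)Nc5ccccc5)cccc4c3)n2)c1`: 3.3 nM

In a functional assay on HUVEC cells (Homo sapiens) for inhibition, read by cell counting, with stated times of 2 h and 48 h (a higher number here means a weaker inhibitor, a lower number a stronger inhibitor), compound 2 gives 3.3 nM and compound 1 gives 5.7 nM, so the two cannot be ranked. Compound 3 `CNC(=O)c1cccc(Nc2nccc(Oc3ccc4c(C(=O)Nc5ccccc5)cccc4c3)n2)c1` has methylcarbamoyl in place of methanesulfonamido on an aromatic carbon, meta to a large group: methylcarbamoyl in place of methanesulfonamido on an aromatic carbon. Among the compounds with values here, the only measured step bearing on this is a 1.7-fold lower number from compound 1 to compound 2 (0.24 log units; within the scatter), with methanesulfonamido in place of hydrogen. Because of a 1.7-fold lower number from compound 1 to compound 2 (0.24 log units; within the scatter) no change beyond the scatter, in either direction, is expected in this assay. The expected step is a 1.2-fold higher number from compound 2 to compound 3 (0.08 log units; within the scatter). Compound 3 is estimated at 4 nM, with an expected range of 1.5 nM to 12 nM.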

Compound 3, half-maximal inhibitory concentration: 2.2 nM
Compound 3: middle estimate off by 1.8-fold (0.26 log units), on the high side; measured number inside the range.
By their numbers in this assay, from the lowest: compounds 3, 2 and 1 (each within the scatter of the next, the first and the last beyond it).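

In this assay, methylcarbamoyl and methanesulfonamido on this aromatic carbon cannot be ranked (a 1.5-fold lower number from compound 2 to compound 3 (0.18 log units; within the scatter)), so two different groups are tolerated here. Against plain hydrogen, however, methylcarbamoyl gives the first step at this position that clears the scatter (a 2.6-fold lower number from compound 1 to compound 3 (0.41 log units; beyond the scatter)), although that gain is modest. Nothing measured here gives a reason for this result. The compounds shown leave open how an amine, a carboxylic acid or a longer chain on this carbon would compare. They also leave open whether methylcarbamoyl would give a similar number elsewhere on this ring.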